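A few compounds are considered here, and "the series" means these few. Any claim that something is new, unique, unknown or untested is made for them only; others in the source may bear on it.

Compound 1 `C/C(=N\NC(=O)/C(C#N)=C/N(C)C)c1ccc(NS(=O)(=O)c2ccc(Cl)cc2)cc1` and compound 2 `CCOC(=O)c1c(/C=C/c2ccccc2)c(C#N)c(=O)n(/N=C(\C)c2ccc(NS(=O)(=O)c3ccc(Cl)cc3)cc2)c1N` share a 4-chlorophenylsulfonamide-bearing hydrazone arm. In a functional assay on HepG2 cells (Homo sapiens) for cytotoxicity, read by sulforhodamine B assay, with a stated time of 48 h (on this read-out lower numbers stand for stronger inhibition and higher numbers for weaker inhibition), compound 1 gives 19400 nM, while compound 2 gives 10700 nM. These two numbers lie within the usual scatter of each other, so nothing separates compound 2 from compound 1 on this read-out; compound 2 simply stands as one of two closely placed values.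

Compound 3 `CCOC(=O)c1c(-c2ccc(Cl)cc2)c(C#N)c(=O)n(/N=C(\C)c2ccc(NS(=O)(=O)c3ccc(Cl)cc3)cc2)c1N` is built on the core of compound 2 and differs in a single position: 4-chlorophenyl in place of 2-phenylethenyl on an aromatic carbon. Both the leaving and the entering group carry a six-membered aromatic ring of carbon only; the change removes the double bond outside aromatic rings and brings in a chlorine.

Going by the values given here, no measured pair shows what such an exchange does in this assay, and the two known values themselves differ by less than the scatter. The expectation for compound 3 is therefore a step from compound 2 that stays within the scatter, a 1.1-fold higher number from compound 2 to compound 3 (0.05 log units; within the scatter), in no firm direction. Compound 3 is estimated at 12000 nM, with a range from 4000 nM to 40000 nM.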

Compound 3, half-maximal inhibitory concentration: 20200 nM
Compound 3: middle estimate off by 1.7-fold (0.23 log units), on the low side, and the stated range covers the measured number.
By their numbers in this assay, from the lowest: compounds 2, 1 and 3 (each within the scatter of the next).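

Going by these compounds alone, this pair gives the first step that changes one place only. On the aromatic carbon opposite the ring nitrogen, in this assay, 4-chlorophenyl in place of 2-phenylethenyl gives a 1.9-fold higher number from compound 2 to compound 3 (0.28 log units; within the scatter) and so cannot be told apart from the scatter. At this position, therefore, the double bond outside aromatic rings can go and a chlorine can come in without any change that this read-out can resolve, as long as a six-membered aromatic ring of carbon only remains on the group. Nothing measured here speaks to the reasons for these values.

What the compounds shown leave open is how the two parts of this exchange act alone, since a plain phenyl group at the same carbon would separate the loss of the double bond from the arrival of the chlorine. They also leave open whether this position accepts a group with no aromatic ring at all, such as a methyl group, an amine or a carboxylic acid, with a number that moves clear of the scatter.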